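A few compounds are considered here, and "the series" means these few. Any claim that something is new, unique, unknown or untested is made for them only; others in the source may bear on it.

In an ADME assay on HEK293 cells (Homo sapiens) for cytotoxicity, read by resazurin assay, with a stated time of 48 h (on this read-out higher numbers stand for lower toxicity in this test and lower numbers for higher toxicity in this test), three compounds sharing one core have been measured. Compound 1 `O=S(=O)(Nc1ccc2oc(-c3ccccc3)nc2c1)c1cccc(F)c1` gives 68000 nM, compound 2 `O=S(=O)(Nc1ccc2oc(-c3ccccc3)nc2c1)c1ccc(Cl)cc1` gives 65000 nM and compound 3 `COc1ccccc1S(=O)(=O)Nc1ccc2oc(-c3ccccc3)nc2c1` gives 41000 nM. Compound 3 stands within the scatter of both others, so the three cannot be ranked. Compound 4 `COc1ccc(S(=O)(=O)Nc2ccc3oc(-c4ccccc4)nc3c2)cc1` has the same atoms as compound 3, joined differently: 4-methoxyphenyl in place of 2-methoxyphenyl on a sulfonyl sulfur. This places 4-methoxyphenyl in place of 2-methoxyphenyl on a sulfonyl sulfur.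

Within the data shown here, no measured step tests this exact exchange. The closest evidence comes from the three measured exchanges of the group at that same place: a 1.0-fold lower number from compound 1 to compound 2 (0.02 log units; within the scatter), a 1.7-fold lower number from compound 1 to compound 3 (0.22 log units; within the scatter) and a 1.6-fold lower number from compound 2 to compound 3 (0.20 log units; within the scatter). All three lie within the scatter, so no step beyond the scatter is expected in this assay here. The estimated step is a 1.2-fold higher number from compound 3 to compound 4 (0.09 log units; within the scatter), which is expected to remain within the scatter. The expected value for compound 4 is 50000 nM, with an estimated range from 25000 nM to 90000 nM.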

Compound 4, half-maximal cytotoxic concentration: 91000 nM
Beside the measured number, compound 4's estimate is 1.8-fold (0.26 log units) below it; measured number above the stated range.
By their numbers in this assay, from the lowest: compounds 3, 2, 1 and 4 (each within the scatter of the next, the first and the last beyond it).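

In this assay, exchanging 2-methoxyphenyl for 4-methoxyphenyl on the sulfonyl sulfur gives a 2.2-fold higher number from compound 3 to compound 4 (0.35 log units; beyond the scatter), the only step among these four compounds that lies beyond the scatter, and it arises between two groups with the same atoms. The other two steps to compound 4 do not separate it from its neighbours: a 1.4-fold higher number from compound 2 to compound 4 (0.15 log units; within the scatter) and a 1.3-fold higher number from compound 1 to compound 4 (0.13 log units; within the scatter). This position therefore responds to how the same atoms are joined, although only compound 3 and compound 4 can be told apart.

Nothing shown here explains why these two isomeric groups differ. As far as these compounds go, it remains open whether a phenyl ring carrying an amine or a carboxylic acid, or a longer chain in place of methoxy, would move the number any further at this position.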